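Three Limits, One Shared Change, One Expected Value

The compounds below may be only part of what the source reports. "The series", "measured", "known", "first", "only" and "open" are said of these compounds alone.

Compound 1, `Cc1cc(=O)n([C@@H]2O[C@H](COP(=O)(O)OP(=O)(O)OP(=O)(O)O)[C@@H](O)[C@H]2O)c(=O)[nH]1`, was tested in an in vitro functional assay on 1321-N1 cells for agonist activity at P2Y purinoceptor 4 (Homo sapiens); a lower number here means that less compound is needed, a higher number that more compound is needed for the effect. In this assay compound 1 gives > 100000 nM, which is a limit of the assay rather than a number. Compound 2, `CCCc1cc(=O)n([C@@H]2O[C@H](COP(=O)(O)OP(=O)(O)OP(=O)(O)O)[C@@H](O)[C@H]2O)c(=O)[nH]1`, differs from compound 1 by ethyl in place of hydrogen on a saturated chain carbon bound to an aromatic carbon. In this assay compound 2 gives > 100000 nM, again a limit. The step that the two limits leave unreadable from compound 1 to compound 2 therefore cannot be sized. Compound 3, `Cc1cc(=O)n([C@@H]2O[C@H](COP(=O)(O)O)[C@@H](O)[C@H]2O)c(=O)[nH]1`, carries a different core: the difference is a hydrogen atom in place of a group of 8 heavy atoms (6 oxygen, 2 phosphorus; no ring), on an oxygen. In this assay compound 3 gives > 100000 nM, also a limit. The step that the two limits leave unreadable from compound 1 to compound 3 is likewise unreadable, since the limit of > 100000 nM in this assay, at which 3 of the 3 values shown sit, holds every measured value at the same ceiling.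

Compound 4, `CCCc1cc(=O)n([C@@H]2O[C@H](COP(=O)(O)O)[C@@H](O)[C@H]2O)c(=O)[nH]1`, is not yet measured. It differs from compound 3 by ethyl in place of hydrogen on a saturated chain carbon bound to an aromatic carbon, the same change as from compound 1 to compound 2, made at the same place. With compound 1 at > 100000 nM and compound 2 at > 100000 nM both sitting at a limit, the step that the limit leaves unreadable from compound 3 to compound 4 is expected to be flat. Compound 4 is therefore estimated to give 200000 nM, most likely reported only as a limit.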

Compound 4, half-maximal effective concentration: > 100000 nM
Compound 4: no number, only a limit; the forecaster's own chance of this, stated with the estimate: 90%; the middle value lies beyond the limit too.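

In this assay compound 4 gives > 100000 nM, which is a limit and not a number. The steps from compound 3 to compound 4 and from compound 2 to compound 4 therefore cannot be read, because every compound sits at the same ceiling: the limit of > 100000 nM in this assay, at which 4 of the 4 values shown sit. The compounds shown leave open whether either structural change has any effect in this assay.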